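Removing a Bromine from the Weakest of Three Hydrazones

The source may hold more compounds than are shown below. What is called first, only, known or untested is meant among the compounds shown, and "the series" means these compounds.

Of the compounds shown here, three have been tested in a functional assay on MCF7 cells (Homo sapiens) for cytotoxicity (on this read-out lower numbers stand for stronger inhibition and higher numbers for weaker inhibition), so far. Compound 1 `COc1ccc(Cn2cc(/C=N\NC(=O)c3c[nH]c4ccccc34)c3ccccc32)cc1` gives 12400 nM, compound 2 `O=C(N/N=C\c1cn(Cc2ccc(Cl)cc2)c2cc(F)ccc12)c1c[nH]c2ccccc12` gives 6000 nM, and compound 3 `COc1ccc(Cn2cc(/C=N\NC(=O)c3c[nH]c4ccc(Br)cc34)c3ccc(F)cc32)cc1` gives 31700 nM, the highest number of the three, and therefore the weakest in this assay, with both gaps beyond the scatter. Compound 4 `COc1ccc(Cn2cc(/C=N\NC(=O)c3c[nH]c4ccccc34)c3ccc(F)cc32)cc1` is compound 3 with one change: hydrogen in place of bromo on an aromatic carbon. For the measured compounds named here, no measured pair shows this change alone, so its size is uncertain. Compound 1, which also lacks the bromo, gives 12400 nM, which points toward a somewhat lower number. Compound 4 is therefore expected to land near 14000 nM, within 6000 nM to 35000 nM, a step of a 2.3-fold lower number from compound 3 to compound 4 (0.35 log units; beyond the scatter) that is estimated to be modest and only a little beyond the scatter.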

Compound 4, half-maximal inhibitory concentration: 13100 nM
For compound 4 the middle estimate is 1.1-fold (0.03 log units) above the measured one; measured number inside the range.
By their numbers in this assay, from the lowest: compound 2; then compounds 1 and 4 (each within the scatter of the next); then compound 3.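

Taken alone, going from the 5-bromo-1H-indol-3-yl group to the 1H-indol-3-yl group gives a 2.4-fold lower number from compound 3 to compound 4 (0.38 log units; beyond the scatter) in this assay, so the weak result of compound 3 goes with the bromo and not with the rest of its structure. Fluoro in place of hydrogen gives a 1.1-fold higher number from compound 1 to compound 4 (0.02 log units; within the scatter), which cannot be told from no change, whereas methoxy in place of chloro gives a 2.2-fold higher number from compound 2 to compound 4 (0.34 log units; beyond the scatter) and so accounts for a separate gap. Nothing measured here explains any of these steps. On these data alone, whether chloro, or an amine or carboxylic acid, on that same aromatic carbon would behave like hydrogen or like bromo remains open. So does whether removing the bromo gives a similar step when chloro replaces methoxy.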